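The compounds below may be only part of what the source reports. "The series", "measured", "known", "first", "only" and "open" are said of these compounds alone.

Values measured in an ADME assay on L6 cells (Rattus norvegicus) for cytotoxicity, read by resazurin assay, with a stated time of 70 h; on this read-out lower numbers stand for stronger inhibition and higher numbers for weaker inhibition:
- compound 1 `CC(=O)Oc1ccc2c(c1)C(C)=CC(C)(C)N2Cc1cccc(C#N)c1`: 31000 nM
- compound 2 `CC(=O)Oc1ccc2c(c1)C(C)=CC(C)(C)N2Cc1cccc(Cl)c1`: 29000 nM
- compound 3 `CC(=O)Oc1ccc2c(c1)C(C)=CC(C)(C)N2Cc1cccc(C(F)(F)F)c1`: 27000 nM

Compound 2 gives 29000 nM and cannot be told apart from compound 1 or compound 3, since all three numbers lie within the scatter of each other.

The step under consideration leads to compound 4 `CC(=O)Oc1ccc2c(c1)C(C)=CC(C)(C)N2C`: hydrogen in place of 3-chlorophenyl on a saturated chain carbon bound to a nitrogen on an aromatic ring in a ring. Cut one bond further out, this is 3-chlorobenzyl to methyl.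

Three measured steps are nearby: a 1.1-fold lower number from compound 1 to compound 2 (0.03 log units; within the scatter), a 1.1-fold lower number from compound 1 to compound 3 (0.06 log units; within the scatter) and a 1.1-fold lower number from compound 2 to compound 3 (0.03 log units; within the scatter). All stay within the scatter, but each only exchanges one group on an aromatic carbon. Within the data shown here, none removes the 3-chlorophenyl, so the data hold no direct precedent for this change, and their flatness says little about it.

A moderate shift toward weaker inhibition in this assay is expected, held with low confidence. The estimated move is a 2.1-fold higher number from compound 2 to compound 4 (0.32 log units; beyond the scatter). Compound 4 is estimated at 60000 nM, with an expected range of 25000 nM to 150000 nM.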

Compound 4, half-maximal inhibitory concentration: 41000 nM
Compound 4: middle estimate off by 1.5-fold (0.17 log units), on the high side; the range from low to high includes it.
By their numbers in this assay, from the lowest: compounds 3, 2, 1 and 4 (each within the scatter of the next).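

In this assay, the change at this position goes beyond exchanging a group on an aromatic carbon: the whole substituted phenyl leaves, giving a 1.4-fold higher number from compound 2 to compound 4 (0.15 log units; within the scatter) and, with the 3-cyanophenyl lost instead, a 1.3-fold higher number from compound 1 to compound 4 (0.12 log units; within the scatter). Neither step leaves the scatter, so among these compounds, the read-out does not depend on the aromatic ring at this position, and 3-chlorobenzyl and methyl cannot be told apart. No supporting data bear on this result.

Still open, on these data alone, is whether a carboxylic acid or an amine on the benzyl group, or a longer chain in its place, would give a step beyond the scatter. As far as these compounds go, the shared core also stays unchanged throughout, so it remains unknown whether the same flatness would hold with a free hydroxyl in place of the acetyl ester.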